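The source may report more compounds than this note shows. Statements on the series, on what has been measured and on what is new or still open speak of the compounds shown alone.

Going by the values given here, in a functional assay on K562 cells (Homo sapiens) for inhibition, read by trypan blue exclusion, with a stated time of 72 h (on this read-out higher numbers stand for weaker inhibition and lower numbers for stronger inhibition), compound 3 (`Cn1c(=O)c(S(=O)(=O)Nc2ccc(F)cc2F)cc2cnc(Nc3ccc4[nH]ccc4c3)nc21`) stands at 5000 nM and is level with compound 1 (`Cn1c(=O)c(S(=O)(=O)c2ccc(C(=O)O)cc2)cc2cnc(Nc3ccc4[nH]ccc4c3)nc21`) at 5000 nM as the lowest number so far, while compound 2 (`Cn1c(=O)c(S(=O)(=O)Cc2ccc(F)cc2)cc2cnc(Nc3ccc4[nH]ccc4c3)nc21`) reads 30000 nM at the high end. Compound 4 (`Cn1c(=O)c(S(=O)(=O)c2ccc(N)cc2F)cc2cnc(Nc3ccc4[nH]ccc4c3)nc21`) carries 4-amino-2-fluorophenyl in place of (2,4-difluorophenyl)amino on a sulfonyl sulfur. Compound 1 also holds a substituted phenyl on the sulfur, and its step to the (2,4-difluorophenyl)amino group is flat (no change at the digits printed from compound 1 to compound 3 (within the scatter)); only the 4-fluorobenzyl group stands apart (a 6.0-fold lower number from compound 2 to compound 3 (0.78 log units; beyond the scatter)). In this assay a small step toward a lower number is therefore expected (a 2.0-fold lower number from compound 3 to compound 4 (0.30 log units; within the scatter)), with no large move foreseen. For compound 4 the expected value is 2500 nM with an estimated range from 400 nM to 10000 nM (estimates only).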

Compound 4, half-maximal inhibitory concentration: 1500 nM
Beside the measured number, compound 4's estimate is 1.7-fold (0.22 log units) above it, within the range that was stated.
By their numbers in this assay, from the lowest: compound 4; then compounds 1 and 3 (each within the scatter of the next); then compound 2.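

In this assay, going by these compounds alone, 4-amino-2-fluorophenyl on the sulfonyl sulfur is the first group to separate from the level shared by the earlier pair, with a 3.3-fold lower number from compound 3 to compound 4 (0.52 log units; beyond the scatter) and a 3.3-fold lower number from compound 1 to compound 4 (0.52 log units; beyond the scatter). Against 4-fluorobenzyl the gap reaches a 20-fold lower number from compound 2 to compound 4 (1.30 log units; beyond the scatter), so changes at this one position alone span a large step. Nothing available bears on why these groups differ.

Whether the amine or the fluorine accounts for the step stays open. A plain phenyl, or a phenyl carrying only the amine, on the sulfur would separate the two.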